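Bromo to chloro on the 4-aryl compounds

The source may hold more compounds than are shown below. What is called first, only, known or untested is meant among the compounds shown, and "the series" means these compounds.

Measured so far in a functional assay on NB-4 cells (Homo sapiens) for cytotoxicity, read by CCK-8 assay, with a stated time of 24 h; on this read-out higher numbers stand for weaker inhibition and lower numbers for stronger inhibition
compound 1 `C=CC(=O)N1C(=O)CC(C)Sc2ccccc21` - 227000 nM
compound 2 `C=CC(=O)N1C(=O)CC(c2ccc(Br)cc2)Sc2ccccc21` - 59400 nM
Not yet measured: compound 3 `C=CC(=O)N1C(=O)CC(c2ccc(Cl)cc2)Sc2ccccc21`

Going by the values given here, compound 2 has the lower of the two numbers in this assay so far. The next change, to compound 3, is chloro in place of bromo on an aromatic carbon, para to a large group (chloro in place of bromo on an aromatic carbon). Among the compounds with values here, the only measured step is a 3.8-fold lower number from compound 1 to compound 2 (0.58 log units; beyond the scatter) and it bears on this only loosely, as it replaced methyl with 4-bromophenyl on a saturated ring carbon. No halogen exchange has been measured. The expected step is small, within the scatter, with no direction favoured (a 1.1-fold higher number from compound 2 to compound 3 (0.04 log units; within the scatter)). The estimated value for compound 3 is 65000 nM (expected range 33000 nM to 125000 nM).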

Compound 3, half-maximal inhibitory concentration: 22600 nM
Estimate against measurement, compound 3: 2.9-fold (0.46 log units) above; measured number below the stated range.
By their numbers in this assay, from the lowest: compound 3; then compound 2; then compound 1.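

In this assay, chloro in place of bromo on an aromatic carbon, para to a large group, gives a 2.6-fold lower number from compound 2 to compound 3 (0.42 log units; beyond the scatter), so the halogen at this position does alter the read-out. Against the methyl compound, the swap to the chlorinated aryl group gives a 10-fold lower number from compound 1 to compound 3 (1.00 log units; beyond the scatter), the widest step in the series so far. No evidence at hand explains either step.

Two halogens set no trend. Going by these compounds, what fluoro, methoxy or an amine would give on the same aromatic carbon remains open.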